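The source may report more compounds than this note shows. Statements on the series, on what has been measured and on what is new or still open speak of the compounds shown alone.

In a functional assay on MDA-MB-436 cells (Homo sapiens) for antiproliferative activity, read by MTT assay, with a stated time of 48 h (a lower number here means a stronger inhibitor, a higher number a weaker inhibitor), three compounds sharing one core have been measured so far. Compound 1 (`CCCNC(=O)N1CCN(c2ncnc3sc(-c4ccc(N5CCN(C)CC5)cc4)cc23)CC1`), with propyl on the amide-type nitrogen, gives 12400 nM. Compound 2 (`CN1CCN(c2ccc(-c3cc4c(N5CCN(C(=O)Nc6ccccc6)CC5)ncnc4s3)cc2)CC1`), with phenyl there, gives 7090 nM, and compound 3 (`CN1CCN(c2ccc(-c3cc4c(N5CCN(C(=O)Nc6ccc(C#N)cc6)CC5)ncnc4s3)cc2)CC1`), with 4-cyanophenyl, gives 5010 nM. Compound 3 therefore stands level with compound 2 within the scatter, and its number is clearly lower than that of compound 1, as shown by a 2.5-fold lower number from compound 1 to compound 3 (0.39 log units; beyond the scatter). The phenyl exchange gives a 1.7-fold lower number from compound 1 to compound 2 (0.24 log units; within the scatter).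

Compound 4 (`CN1CCN(c2ccc(-c3cc4c(N5CCN(C(=O)Nc6ccc(OC(F)(F)F)cc6)CC5)ncnc4s3)cc2)CC1`) differs from compound 3 at a single place: trifluoromethoxy in place of cyano on an aromatic carbon. Trifluoromethoxy takes the place of cyano on an aromatic carbon, para to a large group. Within the data shown here, no measured step covers this exchange directly. The closest evidence is the introduction of cyano in place of hydrogen on an aromatic carbon, a 1.4-fold lower number from compound 2 to compound 3 (0.15 log units; within the scatter). Among the measured compounds shown here, the largest step is the modest one from propyl to 4-cyanophenyl, so the evidence is thin and rests on only three compounds. No step beyond the scatter is therefore expected in this assay, and no direction is favoured. The step estimated for compound 4 reads a 1.0-fold lower number from compound 3 to compound 4 (0.00 log units; within the scatter). For compound 4 the expected value is 5000 nM, with an estimated range from 2200 nM to 11000 nM.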

Compound 4, half-maximal inhibitory concentration: 6250 nM
For compound 4 the middle estimate is 1.3-fold (0.10 log units) below the measured one, and the stated range covers the measured number.
By their numbers in this assay, from the lowest: compounds 3, 4, 2 and 1 (each within the scatter of the next, the first and the last beyond it).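

In this assay, the position on an aromatic carbon para to a large group now tolerates two quite different groups without a readable change: trifluoromethoxy in place of cyano gives a 1.2-fold higher number from compound 3 to compound 4 (0.10 log units; within the scatter), and trifluoromethoxy in place of hydrogen gives a 1.1-fold lower number from compound 2 to compound 4 (0.05 log units; within the scatter). Hydrogen, cyano and trifluoromethoxy therefore stand level at this position, so none of the three exchanges shown there separates its pair of compounds beyond the scatter. The comparison with the propyl compound also differs slightly: 4-(trifluoromethoxy)phenyl in place of propyl gives a 2.0-fold lower number from compound 1 to compound 4 (0.30 log units; within the scatter), which stays within the scatter, whereas 4-cyanophenyl in place of propyl gave a 2.5-fold lower number from compound 1 to compound 3 (0.39 log units; beyond the scatter), which lies just beyond it, and nothing measured here bears on why this position responds so little.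

The compounds shown leave open whether any group at this position could move the number beyond the scatter, for instance a primary amine, a carboxylic acid or a longer alkyl chain. They also leave open whether a substituent elsewhere on this aromatic ring, or a change to the shared core itself, would matter more than the exchanges seen so far.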